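Trimming one methyl from the core of compound 2

The compounds below may be only part of what the source reports. "The series", "measured", "known", "first", "only" and "open" are said of these compounds alone.

Of the compounds shown here, two have been measured in an assay on cells for inhibition of cytochrome P450 11B2, mitochondrial (Homo sapiens), read by HTRF; on this read-out lower numbers stand for stronger inhibition and higher numbers for weaker inhibition: compound 2 `CC1(C)CN(c2cccnc2)C(=O)c2ccc(Cl)cc21` and compound 1 `CCC(=O)NCc1cncc(N2C(=O)c3ccc(Cl)cc3C2(C)C)c1`. In this assay compound 1 gives 282 nM, while compound 2 gives 1540 nM, the higher of the two numbers, a gap beyond the usual scatter. Compound 3 `CC1CN(c2cccnc2)C(=O)c2ccc(Cl)cc21` differs from compound 2 by hydrogen in place of methyl on a saturated ring carbon. Among the compounds with values here, no measured pair shows this change, so no direction beyond the scatter is expected. The step from compound 2 to compound 3 is estimated at a 1.3-fold higher number from compound 2 to compound 3 (0.11 log units; within the scatter). Compound 3 is expected to give 2000 nM in this assay, within 800 nM to 5000 nM.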

Compound 3, half-maximal inhibitory concentration: 164 nM
For compound 3 the middle estimate is 12-fold (1.09 log units) above the measured one; the measured number lies below the stated range.
By their numbers in this assay, from the lowest: compounds 3 and 1 (each within the scatter of the next); then compound 2.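

In this assay, this saturated ring carbon responds strongly to the loss of one methyl: hydrogen in place of methyl gives a 9.4-fold lower number from compound 2 to compound 3 (0.97 log units; beyond the scatter). Within the data shown here, no earlier pair isolated this position, so this is the first evidence that a single methyl here can shift the read-out beyond the scatter. Nothing available accounts for the size of the step.

Still open, going by these compounds, is how an ethyl or hydroxyl group on this carbon would read. On these data alone, it is also open whether the same change would hold with the propionamide-bearing side chain of compound 1 on the pyridine.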